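Adding a Second Methoxy Group to Compound 1

A few compounds are considered here, and "the series" means these few. Any claim that something is new, unique, unknown or untested is made for them only; others in the source may bear on it.

Among the compounds with values here, compound 1 `COc1ccc(-c2cc(/C=C/C(=O)c3ccc(N)cc3)[nH]n2)cc1` is the only compound here with a number rather than a limit in a functional assay on MDA-MB-435 cells (Homo sapiens) for inhibition, read by sulforhodamine B assay, with a stated time of 48 h (on this read-out lower numbers stand for higher toxicity in this test and higher numbers for lower toxicity in this test), where compound 1 gives 38200 nM. Compound 2 `COc1cc(-c2cc(/C=C/C(=O)c3ccc(F)c(F)c3)[nH]n2)cc(OC)c1OC` gives > 100000 nM, which is a limit of the assay and not a number, namely (the limit of > 100000 nM in this assay, at which 1 of the 2 values shown sits). Compound 3 `COc1ccc(-c2cc(/C=C/C(=O)c3ccc(N)cc3)[nH]n2)cc1OC` differs from compound 1 by methoxy in place of hydrogen on an aromatic carbon. Within the data shown here, no measured pair shows this change, so the step is expected to stay within the usual scatter, in no clear direction. Compound 3 is estimated at 40000 nM, with a range from 15000 nM to 100000 nM. The expected step is a 1.0-fold higher number from compound 1 to compound 3 (0.02 log units; within the scatter).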

Compound 3, concentration lethal to 50% of the cells: 40800 nM
For compound 3 the middle estimate is 1.0-fold (0.01 log units) below the measured one, within the range that was stated.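

In this assay, within the data shown here, methoxy in place of hydrogen on an aromatic carbon, ortho to a methoxy group, gives a 1.1-fold higher number from compound 1 to compound 3 (0.03 log units; within the scatter), the first step between measured compounds that differ in one place. Among these compounds, a second methoxy group at this place therefore leaves the read-out within the usual scatter, which the earlier compounds could not show. On these data alone, whether a hydroxyl or an ethoxy group at this place would move the number beyond the scatter stays open. Nothing given here accounts for this result.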